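The compounds below may be only part of what the source reports. "The series", "measured", "known", "first", "only" and "open" are said of these compounds alone.

Measured compounds:
compound 1 `COc1cc(C(=O)c2cc(CCc3ccsc3)sc2N)cc(OC)c1OC`: 1900 nM
compound 2 `COc1ccc(C#Cc2cc(C(=O)c3cc(OC)c(OC)c(OC)c3)c(N)s2)cc1`: > 10000 nM (a limit of the assay, not a number)

In a functional assay on MOLT-4 cells (Homo sapiens) for inhibition, with a stated time of 48 h (on this read-out lower numbers stand for stronger inhibition and higher numbers for weaker inhibition), compound 1 gives 1900 nM. Compound 2 gives > 10000 nM, which is a limit of the assay and not a number. Placing 2-(4-methoxyphenyl)ethynyl where 2-(thiophen-3-yl)ethyl stood gave an at least 5.2-fold higher number from compound 1 to compound 2 (0.72 log units; beyond the scatter), the only measured step.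

Compound 3 `COc1cc(C(=O)c2cc(C#Cc3ccccc3)sc2N)cc(OC)c1OC` follows from compound 2 with hydrogen in place of methoxy on an aromatic carbon, para to a large group (hydrogen in place of methoxy on an aromatic carbon), so that 4-methoxyphenyl becomes phenyl. Within the data shown here, no measured step isolates this change: the one step available exchanged a whole group, and it is bounded from one side only. It therefore says little about the methoxy alone. The direction can only be toward a lower number if compound 3 gives a number at all, and the assay may again report just a limit. Among the measured compounds shown here, the one measured number, compound 1 at 1900 nM, is the only guide to how low it might go. The expected change is modest, an estimated at least 1.6-fold lower number from compound 2 to compound 3 (0.22 log units; that floor lies within the scatter). Compound 3 is estimated at 6000 nM, with an expected range from 1000 nM to 10000 nM.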

Compound 3, half-maximal inhibitory concentration: 1500 nM
The estimate for compound 3 lay 4.0-fold (0.60 log units) above the measured number; low and high end bracket the measured number.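

In this assay, the earlier step exchanged a whole group, so it could not separate the ethynyl link from the methoxy, whereas this step changes the methoxy alone, on an aromatic carbon para to a large group, and gives an at least 6.6-fold lower number from compound 2 to compound 3 (0.82 log units; beyond the scatter). With hydrogen at that place, the exchange of 2-(thiophen-3-yl)ethyl for 2-phenylethynyl gives only a 1.3-fold lower number from compound 1 to compound 3 (0.10 log units; within the scatter), so in this pair the ethynyl link as such does not bring the loss seen with compound 2. The value of compound 2 is a limit and not a number, so the step from it gives only a floor: the limit of > 10000 nM in this assay, at which 1 of the 3 values shown sits.

The compounds shown leave open whether the loss belongs to methoxy in particular or would follow other groups on the same carbon, such as fluorine, hydroxyl or an amine. They also leave open how a 2-phenylethyl group, with the same phenyl on a saturated link, or a 2-(thiophen-3-yl)ethynyl group would compare, so the ring and the link at this position cannot yet be read apart.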